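The source may report more compounds than this note shows. Statements on the series, on what has been measured and on what is new or still open speak of the compounds shown alone.

Measured in an ADME assay on MT4 cells (Homo sapiens) for cytotoxicity, read by MTT assay; on this read-out higher numbers stand for lower toxicity in this test and lower numbers for higher toxicity in this test:
- compound 1 `O=C(CSc1nc(Cc2c(F)cccc2F)cc(=O)[nH]1)c1ccccc1`: > 67000 nM (a limit)
- compound 2 `Cc1c(Cc2c(F)cccc2F)nc(SCc2ccccc2)[nH]c1=O`: > 70000 nM (a limit)
- compound 3 `Cc1c(Cc2c(F)cccc2F)nc(SCc2ccc([N+](=O)[O-])cc2)[nH]c1=O`: > 37000 nM (a limit)

Compound 3 stands only at a limit, > 37000 nM, and the other two values are limits as well. The next compound is compound 4 `Cc1ccc(CSc2nc(Cc3c(F)cccc3F)c(C)c(=O)[nH]2)c(C)c1`, with 2,4-dimethylphenyl in place of 4-nitrophenyl on a saturated chain carbon bound to a sulfur. Among the measured compounds shown here, the only measured step bearing on this change is a step that the two limits leave unreadable from compound 2 to compound 3, so no step beyond the scatter is expected in this assay. Another limit is the likely report. The estimated step is a step that the limit leaves unreadable from compound 3 to compound 4. Compound 4 is expected at 50000 nM, with an estimated range of 20000 nM to 90000 nM.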

Compound 4, half-maximal cytotoxic concentration: > 65000 nM
Compound 4 ended at the assay's limit (the forecaster's own chance of this, stated with the estimate: 75%); middle value at least 1.3-fold (0.11 log units) away from the limit.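

In this assay, among the compounds shown here, compound 4 gives > 65000 nM, which is a limit, so no step from it to compound 2 or compound 3 can be read. The compounds shown leave open whether phenyl, 4-nitrophenyl and 2,4-dimethylphenyl differ at all in this assay, since every value is a limit.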